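The compounds below may be only part of what the source reports. "The series", "measured", "known", "first", "only" and "open" are said of these compounds alone.

Going by the values given here, in a functional assay on RT-112 cells (Homo sapiens) for antiproliferative activity, read by MTT assay, with a stated time of 72 h (on this read-out higher numbers stand for weaker inhibition of growth and lower numbers for stronger inhibition of growth), compound 1 `COc1cc(Nc2ncnc3c(NC(=O)Nc4cc(Cl)c(Cl)cc4Cl)cccc23)cc(OC)c1` gives 4890 nM and compound 2 `COc1cc(Nc2ncnc3c(NC(=O)Nc4cc(C)cc(C)c4)cccc23)cc(OC)c1` gives 10100 nM, the higher of the two numbers so far. Compound 3 `COc1cc(Nc2ncnc3c(NC(=O)Nc4ccc(C(F)(F)F)cc4)cccc23)cc(OC)c1` is not yet measured. It carries 4-(trifluoromethyl)phenyl in place of 3,5-dimethylphenyl on an amide-type nitrogen. Among the compounds with values here, the only measured step at this place is a 2.1-fold higher number from compound 1 to compound 2 (0.32 log units; beyond the scatter), a modest one, and it is a single comparison with a different group. A small shift toward a lower number is therefore expected in this assay, estimated as a 1.7-fold lower number from compound 2 to compound 3 (0.23 log units; within the scatter). For compound 3 the estimated value is 6000 nM, with an expected range of 2500 nM to 14000 nM.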

Compound 3, concentration for 50% growth inhibition: 3920 nM
The estimate for compound 3 lay 1.5-fold (0.18 log units) above the measured number; the range from low to high includes it.
By their numbers in this assay, from the lowest: compounds 3 and 1 (each within the scatter of the next); then compound 2.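

In this assay, 4-(trifluoromethyl)phenyl on the amide-type nitrogen improves on 3,5-dimethylphenyl (a 2.6-fold lower number from compound 2 to compound 3 (0.41 log units; beyond the scatter)), so this place responds to a group other than the trichlorophenyl of compound 1. Against that group, the change gives a 1.2-fold lower number from compound 1 to compound 3 (0.10 log units; within the scatter), so 4-(trifluoromethyl)phenyl and 2,4,5-trichlorophenyl cannot be ranked, and neither the chlorine atoms nor their number is required here. No measurement at hand accounts for these differences. Open, as far as these compounds go, is how unsubstituted phenyl, or a phenyl carrying an amine or a carboxylic acid, would behave at this place.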